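Three Aryl Swaps and an Expectation for Compound 4

A few compounds are considered here, and "the series" means these few. Any claim that something is new, unique, unknown or untested is made for them only; others in the source may bear on it.

Compound 1, `Cn1c(=O)c(=O)n(C2CCCC2)c2nc(N/N=C/c3ccc(C(F)(F)F)cc3)ncc21`, gives 23600 nM in a functional assay on PC-3 cells (Homo sapiens) for antiproliferative activity, read by MTT assay; a lower number here means a stronger inhibitor, a higher number a weaker inhibitor.
Compound 2, `Cc1cc(C)c(/C=N/Nc2ncc3c(n2)n(C2CCCC2)c(=O)c(=O)n3C)c(C)c1`, gives 13900 nM in this assay.
Compound 3, `Cn1c(=O)c(=O)n(C2CCCC2)c2nc(N/N=C/c3ccc(F)cc3Cl)ncc21`, gives 15200 nM in this assay.

All three compounds share the same core and differ only in the aromatic ring attached to the carbon with a double bond to nitrogen. Compound 3 has the second highest of the three numbers, but neither gap is meaningful: a 1.6-fold lower number from compound 1 to compound 3 (0.19 log units; within the scatter) and a 1.1-fold higher number from compound 2 to compound 3 (0.04 log units; within the scatter). The three compounds are, in effect, indistinguishable in this assay.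

Compound 4, `Cc1ccc(/C=N/Nc2ncc3c(n2)n(C2CCCC2)c(=O)c(=O)n3C)cc1C`, continues this series: 3,4-dimethylphenyl in place of 2-chloro-4-fluorophenyl on a carbon with a double bond to nitrogen. Every measured step bears on this change, since each one also exchanges the aromatic ring at this same place: a 1.7-fold lower number from compound 1 to compound 2 (0.23 log units; within the scatter), a 1.6-fold lower number from compound 1 to compound 3 (0.19 log units; within the scatter) and a 1.1-fold higher number from compound 2 to compound 3 (0.04 log units; within the scatter). None of these exchanges moved the number beyond the scatter, even though the rings carried quite different substituents. On that basis the step from compound 3 to compound 4 is expected to be small, a 1.0-fold lower number from compound 3 to compound 4 (0.01 log units; within the scatter), with no clear direction. Compound 4 is therefore estimated at 15000 nM in this assay, with a likely range from 6000 nM to 40000 nM.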

Compound 4, half-maximal inhibitory concentration: 39000 nM
Compound 4: middle estimate off by 2.6-fold (0.41 log units), on the low side, within the range that was stated.
By their numbers in this assay, from the lowest: compounds 2, 3, 1 and 4 (each within the scatter of the next, the first and the last beyond it).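

Until now, no exchange of the aromatic ring on this carbon with a double bond to nitrogen had moved the number in this assay beyond the scatter, but 3,4-dimethylphenyl does so, with a 2.6-fold higher number from compound 3 to compound 4 (0.41 log units; beyond the scatter) and a 2.8-fold higher number from compound 2 to compound 4 (0.45 log units; beyond the scatter), both modest steps. Compound 2 also carries a ring of carbon with methyl groups, so the presence of methyl groups alone does not fix the number here, and the swap from 2-chloro-4-fluorophenyl shows that rings with the same count of heavy atoms can still differ beyond the scatter. The position is therefore not entirely indifferent to the ring it carries, although compound 4 cannot be told apart from compound 1, with a 1.7-fold higher number from compound 1 to compound 4 (0.22 log units; within the scatter), and no measurement shown gives a reason for any of these differences.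

Going by these compounds, the substituents on these rings are only methyl, trifluoromethyl, fluorine and chlorine, so how a ring bearing an amine or a carboxylic acid would behave at this place remains open. Also open, on these data alone, is whether the two methyl groups of compound 4 act together or one alone carries the step, which a ring with a single methyl group could help to settle.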